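Adding an Amino Group to a Weak Sulfonamide

The compounds below may be only part of what the source reports. "The series", "measured", "known", "first", "only" and "open" are said of these compounds alone.

Compound 1 `COc1cc(OC)c(/C=C/S(=O)(=O)Nc2cc(N)c(OC)c(N)c2)c(OC)c1`: 7500 nM
Compound 2 `COc1ccc(NS(=O)(=O)/C=C/c2cc(OC)c(OC)c(OC)c2)cc1`: 35000 nM

Both values come from a functional assay on K562 cells (Homo sapiens) for cytotoxicity, read by trypan blue exclusion, with a stated time of 96 h; on this read-out higher numbers stand for weaker inhibition and lower numbers for stronger inhibition. Compound 2, at 35000 nM, has the higher of the two numbers, so it is the weaker inhibitor of the pair, and its gap to compound 1 lies beyond the scatter.

Compound 3 `COc1ccc(NS(=O)(=O)/C=C/c2cc(OC)c(OC)c(OC)c2)cc1N` differs from compound 2 in a single place: amino in place of hydrogen on an aromatic carbon. Amino takes the place of hydrogen on an aromatic carbon, ortho to a methoxy group, turning 4-methoxyphenyl into 3-amino-4-methoxyphenyl.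

For the measured compounds named here, no measured pair shows this change on its own, so the forecast rests on thin evidence. Amino also appears in compound 1, which gives 7500 nM. Going by the values given here, with that value as the only guide, a moderate step towards a lower number is expected in this assay, although a result within the scatter remains possible. The estimated change is a 2.5-fold lower number from compound 2 to compound 3 (0.40 log units; beyond the scatter). Compound 3 is expected to give 14000 nM. The estimated range for compound 3 runs from 4000 nM to 40000 nM.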

Compound 3, half-maximal inhibitory concentration: 15000 nM
Compound 3: middle estimate off by 1.1-fold (0.03 log units), on the low side; the range from low to high includes it.
By their numbers in this assay, from the lowest: compounds 1 and 3 (each within the scatter of the next); then compound 2.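

In this assay the amino group placed on an aromatic carbon, ortho to a methoxy group, turns 4-methoxyphenyl into 3-amino-4-methoxyphenyl and gives a 2.3-fold lower number from compound 2 to compound 3 (0.37 log units; beyond the scatter) as the measured size of this single change. Before this, amino could be seen only in compound 1, which differs from compound 2 in more than one place, so its share in that gap could not be separated from the other differences. The new pair isolates the change and shows that this one added group, at this position, is enough to move the number by a modest step beyond the scatter, although nothing available explains the step.

Still open, on these data alone, is whether this step depends on the amino group itself, since a hydroxyl, a methylamino or an acetylamino group on the same carbon would show whether other groups move the number in the same way. As far as these compounds go, it is also open whether an amino group on a different carbon of the same six-membered aromatic ring would give a step of similar size, or whether the effect belongs to this position alone.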